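The source may hold more compounds than are shown below. What is called first, only, known or untested is meant among the compounds shown, and "the series" means these compounds.

Compound 1 `CCOc1cccc(-c2ccc([C@H]3S[C@@H](C)C(=O)Nc4c3c(C)nn4-c3ccccc3C)cc2)c1` gives 3500 nM in an assay on isolated protein for agonist activity at Bile acid receptor (Homo sapiens), read by AlphaScreen, with a stated time of 30 min (a higher number here means that more compound is needed for the effect, a lower number that less compound is needed), the highest of the three numbers in hand. Compound 3 `COc1cc([C@H]2S[C@@H](C)C(=O)Nc3c2c(C)nn3-c2ccccc2C)ccc1Oc1ccccc1` gives 1900 nM in this assay, and its gap to compound 1 lies within the scatter. Compound 2 `Cc1nn(-c2ccccc2I)c2c1C(c1ccc(Oc3ccccc3)cc1)SC(C)C(=O)N2` gives 1300 nM in this assay, and its gap to compound 1 lies beyond the scatter. Compound 4 `COc1ccc(Oc2ccc([C@H]3S[C@@H](C)C(=O)Nc4c3c(C)nn4-c3ccccc3C)cc2)cc1` has not been measured. It differs from compound 1 by 4-methoxyphenoxy in place of 3-ethoxyphenyl on an aromatic carbon. Among the measured compounds shown here, no step between measured compounds covers this change. Compound 2 and compound 3 both carry a phenoxy-type group, and the gap from compound 1 to compound 2 is beyond the scatter, so a modest downward step is expected, a 1.9-fold lower number from compound 1 to compound 4 (0.29 log units; within the scatter), possibly still within the scatter. For compound 4 in this assay the estimate is 1800 nM, with a range of 700 nM to 4500 nM.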

Compound 4, half-maximal effective concentration: 2200 nM
Compound 4: the middle estimate sits 1.2-fold (0.09 log units) below what was measured; measured number inside the range.
By their numbers in this assay, from the lowest: compounds 2, 3, 4 and 1 (each within the scatter of the next, the first and the last beyond it).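

At this position, on an aromatic carbon para to a large group, 4-methoxyphenoxy in place of 3-ethoxyphenyl gives a 1.6-fold lower number from compound 1 to compound 4 (0.20 log units; within the scatter) in this assay, so this assay does not separate the two groups. Both groups have 9 heavy atoms, and the 2 hydrogen-bond acceptors of 4-methoxyphenoxy against the 1 of 3-ethoxyphenyl come with no step beyond the scatter. No measurement in hand offers an explanation for this result. Open, from the compounds shown here alone, is how an amine or a carboxylic acid on this aromatic carbon would read in this assay.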